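Chloro in place of trifluoromethyl in compound 3

This account rests on a few compounds, and the source may have more. Where it says the series, first, only, none or still open, it means among the compounds named here.

Within the data shown here, compound 2, `COc1cc2cc(Oc3ccc(NC(=O)Nc4ccc(Cl)c(C(F)(F)F)c4)cc3)c(C)nc2cc1OC`, is the only compound here with a number in a functional assay on EKVX cells (Homo sapiens) for inhibition, read by sulforhodamine B assay, with a stated time of 48 h; on this read-out lower numbers stand for higher toxicity in this test and higher numbers for lower toxicity in this test: compound 2 gives 17600 nM. Compound 1, `COc1cc2cc(Oc3ccc(NC(=O)Nc4cccc(C(F)(F)F)c4)cc3)c(C)nc2cc1OC`, reaches only the limit of the test; in this assay compound 1 gives > 50000 nM, which is a limit and not a number. Among the measured compounds shown here, the one measured step, an at least 2.8-fold lower number from compound 1 to compound 2 (0.45 log units; beyond the scatter), is therefore only a lower bound, because it rests on (the limit of > 50000 nM in this assay, at which 1 of the 2 values shown sits).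

Compound 3, `COc1cc2cc(Oc3ccc(NC(=O)Nc4ccc(Cl)c(Cl)c4)cc3)c(C)nc2cc1OC`, differs from compound 2 in one place: chloro in place of trifluoromethyl on an aromatic carbon. For the measured compounds named here, no measured step covers this exchange; the step that exists concerns a hydrogen becoming chloro at another position, so it says little about a trifluoromethyl becoming chloro. The expected step is accordingly small, a 1.4-fold higher number from compound 2 to compound 3 (0.15 log units; within the scatter), and it lies within the scatter. Compound 3 is thus estimated to give about 25000 nM in this assay, with a range from 8000 nM to 80000 nM, and it may also end at the limit of the test.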

Compound 3, concentration lethal to 50% of the cells: > 100000 nM
Compound 3: a limit, no number; the forecaster's own chance of this, stated with the estimate: 30%; middle value at least 4.0-fold (0.60 log units) away from the limit.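

Among these compounds, the first measured change at this position, with trifluoromethyl leaving and chloro entering, moves the number clearly: the step is an at least 5.6-fold higher number from compound 2 to compound 3 (0.75 log units; beyond the scatter), which lies beyond the scatter. In this assay, where a higher number stands for lower toxicity in this test, compound 3 gives > 100000 nM, which is a limit and not a number. So trifluoromethyl and chloro are not interchangeable here, even though the two groups sit on the same aromatic carbon and neither adds a hydrogen-bond donor or acceptor, and the true size of this step may be larger than printed because it rests on a limit: the limit of > 100000 nM in this assay, at which 1 of the 3 values shown sits.

Going by these compounds, the step between compound 1 and compound 3, which differ in the whole substituted phenyl group, cannot be read because each of the two values is a limit, the other being this one: the limit of > 50000 nM in this assay, at which 1 of the 3 values shown sits. Still open is how this position responds to groups such as a nitrile, an amine or a carboxylic acid, and whether the effect of this exchange would hold on any other cell line.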